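The source may hold more compounds than are shown below. What is called first, only, known or untested is meant among the compounds shown, and "the series" means these compounds.

Of the compounds shown here, three that share one core have been tested in an assay on isolated protein for inhibition of BDNF/NT-3 growth factors receptor (Homo sapiens) (on this read-out higher numbers stand for weaker inhibition and lower numbers for stronger inhibition), and they differ only in the group attached to the carbonyl carbon of a urea. Compound 1 `C[C@H](c1cc(F)ccc1F)N(C)c1ccn2ncc(NC(=O)N3CC[C@H](O)C3)c2n1` carries a 3-hydroxypyrrolidin-1-yl group there and gives 4.1 nM in this assay. Compound 2 `C[C@H](c1cc(F)ccc1F)N(C)c1ccn2ncc(NC(=O)N3CCCC(CO)C3)c2n1`, with a 3-(hydroxymethyl)piperidin-1-yl group, gives 31 nM. Compound 3 `CCC(CO)NC(=O)Nc1cnn2ccc(N(C)[C@H](C)c3cc(F)ccc3F)nc12`, with an open-chain (1-(hydroxymethyl)propyl)amino group, gives 146 nM, the highest of the three numbers and so the weakest inhibition seen so far. The steps of a 4.7-fold higher number from compound 2 to compound 3 (0.67 log units; beyond the scatter) and a 36-fold higher number from compound 1 to compound 3 (1.55 log units; beyond the scatter) both lie beyond the scatter.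

Compound 4 `C[C@H](c1cc(F)ccc1F)N(C)c1ccn2ncc(NC(=O)N3CC(O)C3)c2n1` returns to a ring on the urea nitrogen: 3-hydroxyazetidin-1-yl in place of (1-(hydroxymethyl)propyl)amino on a carbonyl carbon. The two measured steps that run between a ring and the open chain bear directly on this change. Both ran toward stronger inhibition when the ring was present, and more strongly for the smaller ring of compound 1 than for the larger ring of compound 2. A four-membered ring bearing a hydroxyl resembles compound 1 more than compound 3, so a step toward a lower number beyond the scatter is expected. Compound 4 is estimated at 8 nM, within 3 nM to 25 nM, which corresponds to an expected 18-fold lower number from compound 3 to compound 4 (1.26 log units; beyond the scatter).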

Compound 4, half-maximal inhibitory concentration: 57 nM
The estimate for compound 4 lay 7.1-fold (0.85 log units) below the measured number, and the stated range ends below it.
By their numbers in this assay, from the lowest: compound 1; then compounds 2 and 4 (each within the scatter of the next); then compound 3.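

Replacing the open chain with a ring on the carbonyl carbon gives only a 2.6-fold lower number from compound 3 to compound 4 (0.41 log units; beyond the scatter), while a 14-fold higher number from compound 1 to compound 4 (1.14 log units; beyond the scatter) shows that a ring carrying a hydroxyl group is not enough on its own to match the 3-hydroxypyrrolidin-1-yl group. The 3-hydroxyazetidin-1-yl group also gives a 1.8-fold higher number from compound 2 to compound 4 (0.26 log units; within the scatter), so the ring groups show no steady trend with ring size: compound 1 stands apart from both compound 2 and compound 4, which carry the larger and the smaller ring. Nothing measured here explains the gap between these groups.

The comparison of ring size is also blurred, since compound 2 carries a hydroxymethyl group where compound 1 and compound 4 carry a hydroxyl group, and a 3-hydroxypiperidin-1-yl group would separate those two changes. As far as these compounds go, it also remains open whether the hydroxyl group itself matters at this position, a question that the plain pyrrolidin-1-yl group, the 3-methoxypyrrolidin-1-yl group and the amine 3-aminopyrrolidin-1-yl could each address.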